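From methoxy to bromo on a phenyl ring

This account rests on a few compounds, and the source may have more. Where it says the series, first, only, none or still open, it means among the compounds named here.

Three compounds have been measured in a functional assay on A498 cells (Homo sapiens) for cytotoxicity (on this read-out lower numbers stand for stronger inhibition of growth and higher numbers for weaker inhibition of growth), so far:
Compound 1 `COc1ccc(C2=C(c3ccc(SC)cc3)CC3CCCN3C2=O)cc1Br` gives 600 nM
Compound 2 `CSc1ccc(C2=C(c3ccc(C)c(C)c3)C(=O)N3CCCC3C2)cc1` gives 300 nM
Compound 3 `COc1ccc(C2=C(c3ccc(SC)cc3)CC3CCCN3C2=O)cc1` gives 800 nM

Two steps show where compound 3 stands. The first is a 1.3-fold higher number from compound 1 to compound 3 (0.12 log units; within the scatter), so those two compounds cannot be told apart. The second is a 2.7-fold higher number from compound 2 to compound 3 (0.43 log units; beyond the scatter), the only gap here beyond the scatter, and it leaves compound 3 with a clearly higher number than compound 2.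

The unmeasured compound 4 `CSc1ccc(C2=C(c3ccc(Br)cc3)C(=O)N3CCCC3C2)cc1` alters the 4-methoxyphenyl group of compound 3: bromo in place of methoxy on an aromatic carbon. This exact swap has not been measured. The closest evidence is the step of a 2.7-fold higher number from compound 2 to compound 3 (0.43 log units; beyond the scatter), which also concerns replacing the 4-methoxyphenyl group. It points to a small move toward a lower number in this assay, probably inside the scatter. The expected change is a 1.8-fold lower number from compound 3 to compound 4 (0.25 log units; within the scatter) as a best estimate. Compound 4 is estimated at 450 nM, with an expected range from 170 nM to 1100 nM in this read-out.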

Compound 4, concentration for 50% growth inhibition: 7000 nM
Estimate against measurement, compound 4: 16-fold (1.19 log units) below, and the stated range ends below it.
By their numbers in this assay, from the lowest: compounds 2, 1 and 3 (each within the scatter of the next, the first and the last beyond it); then compound 4.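

Replacing methoxy with bromo on this aromatic carbon produces an 8.8-fold higher number from compound 3 to compound 4 (0.94 log units; beyond the scatter) in this assay, a much larger shift than the earlier changes of this ring showed. Compound 4 also stands clearly apart from the other two compounds, with a 12-fold higher number from compound 1 to compound 4 (1.07 log units; beyond the scatter) and a 23-fold higher number from compound 2 to compound 4 (1.37 log units; beyond the scatter) as the steps that separate it. A bromo on the ring is not enough on its own to give this rise: compound 1 carries one and keeps its methoxy, and it stays within the scatter of compound 3.

No measurement shown gives a reason for the rise.
From the compounds shown here alone, whether losing the methoxy or placing bromo on that carbon matters more remains open, and a hydroxyl, a fluoro or an amine on the same carbon could help tell these readings apart.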